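Two Alkynyl Benzamides at the Limit, and a Pyridine Analogue

The source may hold more compounds than are shown below. What is called first, only, known or untested is meant among the compounds shown, and "the series" means these compounds.

The first compound, compound 1 `COc1ccc(C#Cc2ccc(C(=O)N3CCC[C@@H](CO)C3)cc2)c(F)c1`, and the second, compound 2 `COc1ccc(C#Cc2ccc(C(=O)N3CCC[C@@H](CO)C3)cc2)cc1F`, share a core and differ only in the aryl group on the triple-bonded carbon. In a functional assay on TREX cells for negative allosteric modulation of metabotropic glutamate receptor 3 (Rattus norvegicus), read by calcium flux, with a stated time of 2.5 min (a lower number here means a stronger inhibitor, a higher number a weaker inhibitor), compound 1 gives > 10000 nM, which is a limit of the assay and not a number. In this assay compound 2 likewise gives > 10000 nM, again a limit rather than a number. The step from compound 1 to compound 2 is therefore a step that the two limits leave unreadable from compound 1 to compound 2, since both values sit at the limit (the limit of > 10000 nM in this assay, at which 2 of the 2 values shown sit).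

The unmeasured compound 3 `COc1ccc(C#Cc2ccc(C(=O)N3CCC[C@@H](CO)C3)cc2)cn1` is reached from compound 2 by 6-methoxypyridin-3-yl in place of 3-fluoro-4-methoxyphenyl on a triple-bonded carbon. Within the data shown here, the only measured step, from compound 1 to compound 2, gives no readable size, so nothing among the measured compounds shows that a change of the aryl group on the triple-bonded carbon moves the value of this assay out of the limit region. The estimated step that the limit leaves unreadable from compound 2 to compound 3 is expected to stay within the scatter of repeated measurements. Compound 3 is accordingly expected to give about 15000 nM in this assay, with a range from 5000 nM to 50000 nM, most likely reported only as a limit.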

Compound 3, half-maximal inhibitory concentration: > 10000 nM
Compound 3: only a limit was reported (the forecaster's own chance of this, stated with the estimate: 75%); the middle value is on the limit's open side.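

In this assay compound 3 gives > 10000 nM, which is a limit of the assay and not a number. No step from compound 1 or compound 2 to compound 3 can be read, since all the values sit at that limit: the limit of > 10000 nM in this assay, at which 3 of the 3 values shown sit.

The compounds shown leave open how strongly, if at all, any of these three aryl groups on the triple-bonded carbon inhibits in this assay.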